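A Para-Substituent Swap on a Benzylamide Core

This account rests on a few compounds, and the source may have more. Where it says the series, first, only, none or still open, it means among the compounds named here.

Measured so far in an assay on HeLa cells with Bile acid receptor (Homo sapiens) as the target, read by a luciferase reporter, with a stated time of 24 h; a lower number here means that less compound is needed, a higher number that more compound is needed for the effect:
compound 1 `C[S+]([O-])c1ccc(CNC(=O)c2ccc(C(C)(C)C)cc2)cc1` gives 1300 nM
compound 2 `CC(=O)Nc1ccc(CNC(=O)c2ccc(C(C)(C)C)cc2)cc1` gives 2900 nM

Going by the values given here, compound 2 stands at the higher of the two numbers so far; the step of a 2.2-fold higher number from compound 1 to compound 2 (0.35 log units; beyond the scatter) separates it from compound 1. The next compound, compound 3 `CCOc1ccc(CNC(=O)c2ccc(C(C)(C)C)cc2)cc1`, differs from compound 2 by ethoxy in place of acetamido on an aromatic carbon. Among the compounds with values here, only one measured step touches this same aromatic carbon, the one from compound 1 to compound 2, and it was modest though beyond the scatter. Within the data shown here, no measured compound carries ethoxy, so the expectation rests on that single step alone. The step from compound 2 to compound 3 in this assay is expected to be small, a 1.8-fold lower number from compound 2 to compound 3 (0.26 log units; within the scatter), toward a lower number and not clearly beyond the scatter. Compound 3 is therefore estimated at 1600 nM, with a range from 500 nM to 5000 nM.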

Compound 3, half-maximal effective concentration: 160 nM
The estimate for compound 3 lay 10-fold (1.00 log units) above the measured number; measured number outside the range, below it.
By their numbers in this assay, from the lowest: compound 3; then compound 1; then compound 2.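

In this assay, the aromatic carbon para to a large group proves far more sensitive to its substituent than the first pair showed: ethoxy in place of acetamido gives an 18-fold lower number from compound 2 to compound 3 (1.26 log units; beyond the scatter). Ethoxy also improves on the group in compound 1, with an 8.1-fold lower number from compound 1 to compound 3 (0.91 log units; beyond the scatter), so the low number of compound 3 is not just a matter of leaving acetamido behind. The change removes the hydrogen-bond donor of acetamido, but nothing measured here tells why the number falls.

Whether the low number depends on the ethoxy chain itself remains open, since the compounds shown do not include methoxy, a longer chain such as propoxy, or an amine at this carbon. They also leave open whether ethoxy would have the same effect on a different core.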